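Swapping an aryl group on a shared urea core

A few compounds are considered here, and "the series" means these few. Any claim that something is new, unique, unknown or untested is made for them only; others in the source may bear on it.

Measured so far:
compound 1, `CCc1ccc(Nc2cc(NC(=O)Nc3cc(OC)cc(OC)c3)ncn2)cc1`: 66.2%
compound 2, `COc1cc(NC(=O)Nc2cc(Nc3cc(C(F)(F)F)ccc3OC)ncn2)cc(OC)c1`: 59.7%

In a functional assay on HCC827 cells (Homo sapiens) for inhibition, read by MTT assay, with a stated time of 48 h, tested at 10 uM (on this read-out higher numbers stand for more inhibition at the one concentration tested (going by the name of the read-out) and lower numbers for less inhibition), compound 1 gives 66.2% and compound 2 gives 59.7%; the gap between them lies within the usual scatter, so neither stands apart from the other. Compound 3, `COc1cc(NC(=O)Nc2cc(Nc3cc(C)cc(F)c3)ncn2)cc(OC)c1`, differs from compound 1 in one place: 3-fluoro-5-methylphenyl in place of 4-ethylphenyl on a nitrogen on an aromatic ring. Within the data shown here, no measured pair shows a change of this kind, so nothing tells how large a step it brings. Compound 3 is expected to land close to compound 1, with a step of a number 6.2 percentage points lower from compound 1 to compound 3 (within the scatter), not beyond the scatter. Compound 3 is estimated at 60%, between 44% and 76%.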

Compound 3, a percentage reported as inhibition, at one concentration (the size of the read-out at that concentration, not a potency): 62.1%
Compound 3: the middle estimate sits 2.1 percentage points below what was measured, within the range that was stated.
By their numbers in this assay, from the lowest: compounds 2, 3 and 1 (each within the scatter of the next).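

In this assay, putting 3-fluoro-5-methylphenyl in place of 4-ethylphenyl on the nitrogen gives a number 4.1 percentage points lower from compound 1 to compound 3 (within the scatter). This position therefore reads much the same with two differently substituted phenyl groups, one bearing an ethyl chain and the other bearing fluorine and methyl. Nothing available explains this result. As far as these compounds go, what an amine or a carboxylic acid on this phenyl ring would do remains open. So does the question of which change at this position, if any, would move the number beyond the scatter.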